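Imidazole for Oxazole on an Endothelin B Series

This account rests on a few compounds, and the source may have more. Where it says the series, first, only, none or still open, it means among the compounds named here.

Compound 1, `CC(=O)c1ccc(OCc2ccsc2)cc1OC(CCC(=O)O)c1ccccc1C`: 10000 nM
Compound 2, `Cc1ccccc1C(CCC(=O)O)Oc1cc(OCc2ccsc2)ccc1C(N)=O`: 10000 nM
Compound 3, `Cc1ccccc1C(CCC(=O)O)Oc1cc(OCc2ccsc2)ccc1-c1ncco1`: 10000 nM

Of the compounds shown here, three on a shared core have been measured in an assay on cerebellum for binding affinity to Endothelin receptor type B (Rattus norvegicus); a higher number here means a weaker inhibitor, a lower number a stronger inhibitor. Compound 1 gives 10000 nM in this assay, compound 2 gives 10000 nM, and compound 3 gives 10000 nM. The three values lie level with one another: no change at the digits printed from compound 1 to compound 2 (within the scatter), no change at the digits printed from compound 1 to compound 3 (within the scatter) and no change at the digits printed from compound 2 to compound 3 (within the scatter). Compound 3 therefore stands at the same level as both of the others, with no step beyond the scatter in either direction.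

Compound 4, `Cc1ccccc1C(CCC(=O)O)Oc1cc(OCc2ccsc2)ccc1-c1ncc[nH]1`, has not yet been measured. It differs from compound 3 in one place: 1H-imidazol-2-yl in place of 1,3-oxazol-2-yl on an aromatic carbon. The measured steps that bear on this are those exchanging groups at the same aromatic carbon, from an acetyl or carbamoyl to an oxazolyl, and none of them moved the read-out beyond the scatter. For compound 4 no step beyond the scatter is therefore expected in this assay, so that compound 4 is estimated at 10000 nM, between 3000 nM and 30000 nM. The step this estimate implies is no change at the digits printed from compound 3 to compound 4 (within the scatter), which is expected to fall within the scatter.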

Compound 4, half-maximal inhibitory concentration: > 10000 nM
Compound 4 ended at the assay's limit (the forecaster's own chance of this, stated with the estimate: 40%); the middle value lies on the limit itself.
By their numbers in this assay, from the lowest: compounds 1, 2 and 3 (each within the scatter of the next).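

In this assay compound 4 gives > 10000 nM, which is a limit of the assay and not a number. At this aromatic carbon, para to the (thiophen-3-yl)methoxy group, 1H-imidazol-2-yl brings a hydrogen-bond donor that none of the earlier groups at this position, acetyl, carbamoyl and 1,3-oxazol-2-yl, is counted as an addition of here, yet the number comes out no lower than for those compounds. The data give a number no lower from compound 3 to compound 4 (the limit leaves the size open) and a number no lower from compound 2 to compound 4 (the limit leaves the size open) and also a number no lower from compound 1 to compound 4 (the limit leaves the size open) (all three at this aromatic carbon). The size of the steps to compound 4 from compounds 1, 2 and 3 cannot be read, because the result sits at the limit: the limit of > 10000 nM in this assay, at which 1 of the 4 values shown sits.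

Going by these compounds, how far compound 4 lies past that limit stays open.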